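The source may hold more compounds than are shown below. What is called first, only, known or untested is meant among the compounds shown, and "the series" means these compounds.

Measured compounds:
compound 1 `O=C(Nc1ccc(Cl)c(-c2nnc3c(Cl)cccn23)c1)c1ccccn1` in a functional assay on A549 cells (Homo sapiens) for antiproliferative activity, read by MTT assay, with a stated time of 72 h (on this read-out higher numbers stand for weaker inhibition and lower numbers for stronger inhibition), gives > 100000 nM, which is a limit of the assay and not a number.
compound 2 `O=C(Nc1ccc(Cl)c(-c2nnc3c(Cl)cccn23)c1)c1c(F)cccc1Cl` in this assay gives 72300 nM.

For the measured compounds named here, compound 2 thus holds the only numerical value in this assay; the other entry, that of compound 1, is a limit (the limit of > 100000 nM in this assay, at which 1 of the 2 values shown sits). The step to the new compound 3 `O=C(Nc1ccc(Cl)c(-c2nnc3c(Cl)cccn23)c1)c1cccnc1Cl` is 2-chloropyridin-3-yl in place of 2-chloro-6-fluorophenyl on a carbonyl carbon. Going by the values given here, the one measured step that bears on it is the exchange of the acyl ring on the same carbonyl carbon, an at least 1.3-fold lower number from compound 1 to compound 2 (0.14 log units; that floor lies within the scatter), which is at least that floor and lies within the scatter. Compound 3 brings a ring nitrogen back into the acyl group while keeping one chlorine; on that basis compound 3 is expected to land between the two known points, nearer the weak end, with a fair chance that this assay again returns only a limit. The estimated step of a 1.2-fold higher number from compound 2 to compound 3 (0.10 log units; within the scatter) is expected to stay close to the scatter. Compound 3 is therefore estimated at 90000 nM, range 35000 nM to 200000 nM.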

Compound 3, half-maximal inhibitory concentration: 35800 nM
For compound 3 the middle estimate is 2.5-fold (0.40 log units) above the measured one; low and high end bracket the measured number.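

In this assay, for the compounds shown here, the exchange of 2-chloro-6-fluorophenyl for 2-chloropyridin-3-yl on the carbonyl carbon gives a 2.0-fold lower number from compound 2 to compound 3 (0.31 log units; beyond the scatter), the first step at this position that reads beyond the scatter, so the acyl ring on this carbonyl carbon can move the number even though the rest of the molecule stays the same. Against pyridin-2-yl, the same 2-chloropyridin-3-yl group gives an at least 2.7-fold lower number from compound 1 to compound 3 (0.44 log units; beyond the scatter), which shows that an acyl ring with a hetero atom does not by itself hold the series at the weak end. The entry for compound 1 is a limit of the assay and not a number, so this second step is only a floor: the limit of > 100000 nM in this assay, at which 1 of the 3 values shown sits.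

Going by these compounds, whether the lower number of compound 3 belongs to the ring nitrogen, to the loss of fluorine or to where the ring is joined to the carbonyl carbon stays open, as the two groups differ in more than one respect. Also open, on these data alone, is how this assay would read with a cyclohexyl group, an acyl ring carrying an amine or a carboxylic acid, or a longer chain on the carbonyl carbon.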